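A Nitro Group on a Weaker Core

The source may hold more compounds than are shown below. What is called first, only, known or untested is meant among the compounds shown, and "the series" means these compounds.

Compound 1 `CSc1nc(NCCCCNc2ccnc3cc(Cl)ccc23)c(C#N)c(-c2ccccc2)n1` and compound 3 `CSc1nc(NCCCCNc2ccnc3cc(Cl)ccc23)c(C#N)c(-c2cccc([N+](=O)[O-])c2)n1` share one core, while compound 2 `CSc1nc(-c2ccccc2)c(C#N)c(N2CCN(c3ccnc4cc(Cl)ccc34)CC2)n1` and compound 4 `CSc1nc(-c2ccc([N+](=O)[O-])cc2)c(C#N)c(N2CCN(c3ccnc4cc(Cl)ccc34)CC2)n1` share another; the difference between the two cores is not broken down here. In an ADME assay on HeLa cells (Homo sapiens) for inhibition, read by cell counting (a lower number here means a stronger inhibitor, a higher number a weaker inhibitor), compound 1 gives 8500 nM and compound 3 gives 1100 nM. The change between them is nitro in place of hydrogen on an aromatic carbon, and it brought a 7.7-fold lower number from compound 1 to compound 3 (0.89 log units; beyond the scatter). In this assay compound 2 gives > 250000 nM, which is a limit of the assay and not a number; this is the limit of > 250000 nM in this assay, at which 1 of the 3 values shown sits. Compound 4 has not been measured yet. It differs from compound 2 by nitro in place of hydrogen on an aromatic carbon, the same kind of change as from compound 1 to compound 3, though the place is meta to a large group in compound 3 and para to a large group in compound 4. The expectation for compound 4 is an at least 1.6-fold lower number from compound 2 to compound 4 (0.22 log units; that floor lies within the scatter), resting on the size of a 7.7-fold lower number from compound 1 to compound 3 (0.89 log units; beyond the scatter) and on the fact that compound 2 shows only a limit. Compound 4 is therefore estimated at 150000 nM, between 30000 nM and 600000 nM.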

Compound 4, half-maximal inhibitory concentration: 228000 nM
Beside the measured number, compound 4's estimate is 1.5-fold (0.18 log units) below it; measured number inside the range.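

On the second core, in this assay, the change from phenyl to 4-nitrophenyl gives an at least 1.0-fold lower number from compound 2 to compound 4 (0.04 log units; that floor lies within the scatter). Compound 2 gives > 250000 nM, which is a limit of the assay and not a number: the limit of > 250000 nM in this assay, at which 1 of the 4 values shown sits. The step on this core is therefore only a floor, so the result shows neither that the nitro change carries over at its earlier size nor that it is lost, and the two cores cannot be ranked in how they respond: the same change on two cores in this assay, a 7.7-fold lower number (0.89 log units; beyond the scatter) from compound 1 to compound 3 and an at least 1.0-fold lower number (0.04 log units; that floor lies within the scatter) from compound 2 to compound 4; the limit leaves it open whether they differ.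

The compounds shown leave open whether the size of this step depends on the core or on where the nitro stands, as the two pairs differ in both respects. They also leave open whether another group on the same phenyl ring, such as an amine or a carboxylic acid, would move the number in the same direction on each core.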